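Swapping a Nitrophenyl for a Chlorophenyl on the Sulfonyl

The source may report more compounds than this note shows. Statements on the series, on what has been measured and on what is new or still open speak of the compounds shown alone.

Compound 1 `COC(=O)c1cc(=O)c2c(OC)cc(OC)cc2n1C`: > 37900 nM
Compound 2 `COc1ccc(-c2cc(=O)c3c(OC)cc(OC)cc3n2S(=O)(=O)c2cccc([N+](=O)[O-])c2)cc1`: > 39600 nM

In a functional assay on SUP-B15 cells (Homo sapiens) for antiproliferative activity, with a stated time of 72 h (on this read-out higher numbers stand for an effect only at larger amounts of compound and lower numbers for an effect already at smaller amounts), compound 1 gives > 37900 nM, which is a limit of the assay rather than a number (the limit of > 37900 nM in this assay, at which 1 of the 2 values shown sits). Compound 2 likewise gives only a limit, > 39600 nM (the limit of > 39600 nM in this assay, at which 1 of the 2 values shown sits). So compound 2 stands among values where no effect appeared within the tested range. Compound 3 `COc1ccc(-c2cc(=O)c3c(OC)cc(OC)cc3n2S(=O)(=O)c2ccc(Cl)cc2)cc1` differs from compound 2 by 4-chlorophenyl in place of 3-nitrophenyl on a sulfonyl sulfur. Within the data shown here, no measured step of this kind exists here, so a shift beyond the scatter is not expected. Compound 3 is expected to come out near 40000 nM (range 10000 nM to 120000 nM), most likely again as a limit. This estimate means a step that the limit leaves unreadable from compound 2 to compound 3, expected to lie within the scatter.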

Compound 3, half-maximal effective concentration: > 34400 nM
Compound 3 was reported as a limit; the forecaster's own chance of this, stated with the estimate: 75%; the middle value is on the limit's open side.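

Compound 2 and compound 3 both gave only limits, so no step can be read for 4-chlorophenyl in place of 3-nitrophenyl. The compounds shown leave open whether any group on that sulfonyl sulfur gives a measurable value.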